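Chloro in place of hydrogen on compound 3

This account rests on a few compounds, and the source may have more. Where it says the series, first, only, none or still open, it means among the compounds named here.

Of the compounds shown here, three have numbers so far: compound 1 (`O/N=C/c1ccc(-c2cc(O)cc(O)c2)cc1O`), compound 2 (`Oc1cc(O)cc(-c2cc3cc(O)ccc3o2)c1`) and compound 3 (`Oc1cc(O)cc(-c2cnc3cc(O)ccc3c2)c1`). In a functional assay on MDA-MB-231 cells (Homo sapiens) for antiproliferative activity, read by sulforhodamine B assay, with a stated time of 6 days (a higher number here means a weaker inhibitor, a lower number a stronger inhibitor), compound 1 gives 19200 nM, compound 2 gives 46100 nM and compound 3 gives 17400 nM. Compound 3 stands level with compound 1 within the scatter, and compound 2 has the higher number, beyond the scatter.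

The next compound is compound 4 (`Oc1cc(O)cc(-c2cc3ccc(O)cc3nc2Cl)c1`). It carries chloro in place of hydrogen on an aromatic carbon, next to the ring nitrogen (chloro in place of hydrogen on an aromatic carbon). For the measured compounds named here, no measured pair differs in one place only, so the data show no direct precedent for this change. The starting point for the expectation is therefore compound 3 at 17400 nM.

The estimated step of a 1.5-fold lower number from compound 3 to compound 4 (0.16 log units; within the scatter) in this assay is small, leans towards a lower number and is expected to stay within the scatter. Compound 4 is expected at 12000 nM, with an estimated range of 4500 nM to 32000 nM.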

Compound 4, half-maximal inhibitory concentration: 47400 nM
The estimate for compound 4 lay 4.0-fold (0.60 log units) below the measured number, and the stated range ends below it.
By their numbers in this assay, from the lowest: compounds 3 and 1 (each within the scatter of the next); then compounds 2 and 4 (each within the scatter of the next).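

In this assay, for the compounds shown here, chloro in place of hydrogen on the aromatic carbon next to the ring nitrogen provides the first single-place comparison: the step is a 2.7-fold higher number from compound 3 to compound 4 (0.44 log units; beyond the scatter) and is modest in size. This position is therefore not silent, and in this one pair the change moves the number towards weaker inhibition. No measurement is available to explain the step, which stands as an observation only.

A single substitution leaves open whether the rise is specific to chloro or follows from replacing hydrogen at this carbon with other groups; fluoro, methyl or an amine at the same carbon would help separate those readings. From the compounds shown here alone, it also remains open whether chloro on another carbon of this ring gives a step of similar size.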